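Swapping a benzyl for an isopropyl on the purine-like core

The source may report more compounds than this note shows. Statements on the series, on what has been measured and on what is new or still open speak of the compounds shown alone.

Of the compounds shown here, two have been tested so far in a functional assay on HepG2 cells (Homo sapiens) for antiproliferative activity, read by CCK-8 assay, with a stated time of 72 h, tested at 2 uM; a lower number here means a weaker effect, a higher number a stronger effect of the compound at the concentration tested. Compound 1, `Nc1ccccc1NC(=O)c1ccc(Cn2cnc3c(Nc4ccc(-c5ccccn5)cc4)nc(Cl)nc32)cc1`, gives 11.5% in this assay. Compound 2, `Nc1ccccc1NC(=O)c1ccc(CNc2nc(Cl)nc3c2ncn3Cc2ccccc2)cc1`, gives 5.01% in this assay, a number that sits within the usual scatter of the number for compound 1, so the two cannot be told apart with confidence; both show only a weak effect at the concentration tested.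

Compound 3, `CC(C)n1cnc2c(NCc3ccc(C(=O)Nc4ccccc4N)cc3)nc(Cl)nc21`, has not yet been measured. It differs from compound 2 in one place: isopropyl in place of benzyl on an aromatic nitrogen. The rest of the molecule, including the amide-bearing part and the chlorine on the shared core, is unchanged.

Going by the values given here, no step between two measured compounds is available to guide the size of this change. With compound 2 already low, a step of any clear size in either direction is not expected, and a number 1 percentage points higher from compound 2 to compound 3 (within the scatter) is estimated to stay within the scatter. Compound 3 is therefore expected to give about 6% in this assay, with a plausible range from 0% to 18%, because compound 2 gives 5.01% and the change is small.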

Compound 3, a percentage reported as inhibition, at one concentration (the size of the read-out at that concentration, not a potency): 63.8%
Compound 3: the middle estimate sits 57.8 percentage points below what was measured; measured number outside the range, above it.
By their numbers in this assay, from the lowest: compounds 2 and 1 (each within the scatter of the next); then compound 3.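

Replacing the benzyl with isopropyl on the aromatic nitrogen of the five-membered ring gives, in this assay, a number 58.8 percentage points higher from compound 2 to compound 3 (beyond the scatter), which shows that this position is far from indifferent: a change in this one place is enough to turn a weak read-out into a clear effect at the concentration tested. The change removes a six-membered aromatic ring of carbon only and reduces the group from 7 heavy atoms to 3, while neither group carries a hydrogen-bond donor or acceptor, so the counted difference lies in the ring and the number of heavy atoms. No measurement available here explains why the number rises.

As far as these compounds go, a single step cannot separate the loss of the ring from the drop in the number of heavy atoms, so it remains open which of the two matters, or whether both do. From the compounds shown here alone, how a methyl, a cyclopentyl or a longer chain such as n-butyl on this nitrogen would compare also remains open, as does how the effect of compound 3 would change at other concentrations, since the read-out was taken at one concentration only.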